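A new group on the ring nitrogen of compound 1

The source may hold more compounds than are shown below. What is called first, only, known or untested is meant among the compounds shown, and "the series" means these compounds.

Compound 1 `CC(C)(C)OC(=O)N1CCc2c(sc(NC(=O)Nc3ccc(Cl)cc3)c2C(N)=O)C1` gives > 25000 nM as a limit
Compound 2 `CCN1CCc2c(sc(NC(=O)C3(c4ccc(Cl)cc4)CC3)c2C(N)=O)C1` gives > 25000 nM as a limit
Compound 3 `CCN1CCc2c(sc(NC(=O)Nc3ccc(Cl)cc3)c2C#N)C1` gives > 25000 nM as a limit

All three results come from a functional assay (strain AB) with Danio rerio as the target, read by microscopy, with a stated time of 1 h (on this read-out higher numbers stand for an effect only at larger amounts of compound and lower numbers for an effect already at smaller amounts), and none of them is a true number. In this assay compound 1 gives > 25000 nM and this is a limit of the assay, not a number. Compound 2 and compound 3 stand at the same limit, so no order can be drawn among the three.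

Compound 4 `CC(C)(C)OC(=O)CCCN1CCc2c(sc(NC(=O)Nc3ccc(Cl)cc3)c2C(N)=O)C1` keeps the core of compound 1 and changes one group on an amine nitrogen in a ring: 3-(tert-butoxycarbonyl)propyl in place of tert-butoxycarbonyl on an amine nitrogen in a ring is the whole difference. Neither group has a ring or a net charge.

Among the compounds with values here, no two measured compounds differ in one place only, so no measured step can guide this one. The expectation for compound 4 therefore rests on compound 1 and its limit of > 25000 nM as the starting point. Because of the limit of > 25000 nM in this assay, at which 3 of the 3 values shown sit, no step beyond the scatter is expected in this assay and no clear direction either. The expected step is an at least 1.1-fold lower number from compound 1 to compound 4 (0.05 log units; that floor lies within the scatter) and it is only an estimate. A report of a limit alone is the likeliest result. For compound 4 the estimated value is 22000 nM with an expected range from 7000 nM to 40000 nM as its span.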

Compound 4, half-maximal effective concentration: 560 nM
The estimate for compound 4 lay 39-fold (1.59 log units) above the measured number; measured number outside the range, below it.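

Within the data shown here, until this result, every compound in this assay stood at a limit, so nothing showed that any part of these molecules could move the read-out at all. Putting 3-(tert-butoxycarbonyl)propyl in place of tert-butoxycarbonyl on the amine nitrogen in a ring gives an at least 44-fold lower number from compound 1 to compound 4 (1.64 log units; beyond the scatter), which marks this position as one where the read-out responds strongly to a single change, even though neither group has a ring or a net charge and the counts of hydrogen-bond donors and acceptors stay the same. The step can only be stated as a minimum, and its true size stays unknown, because compound 1 has a limit rather than a number: the limit of > 25000 nM in this assay, at which 3 of the 4 values shown sit.

On these data alone, it remains open whether the effect follows the length of the chain or the tert-butyl ester at its end, and a longer chain, or a carboxylic acid at the end of the propyl chain, would help separate the two. As far as these compounds go, it is also open whether this group would have the same effect with changes elsewhere on the shared core.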